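Fluoro Scan on the Benzyl Ring of Compound 1

This account rests on a few compounds, and the source may have more. Where it says the series, first, only, none or still open, it means among the compounds named here.

Measured in a functional assay on HCT-116 cells (Homo sapiens) for antiproliferative activity, with a stated time of 72 h; on this read-out higher numbers stand for weaker inhibition and lower numbers for stronger inhibition:
Compound 1, `O=C(COc1ccc(CN2CC=C(c3c[nH]c4ccc(F)cc34)CC2)cc1)NO`: 949 nM
Compound 2, `Cc1ccc2[nH]cc(C3=CCN(Cc4ccc(OCC(=O)NO)cc4)CC3)c2c1`: 632 nM
Compound 3, `O=C(COc1ccc(C(=O)N2CC=C(c3c[nH]c4ccc(F)cc34)CC2)cc1)NO`: > 5000 nM, a limit of the assay, not a number

Compound 1 carries the higher of the two numbers shown, though the only measured step, a 1.5-fold lower number from compound 1 to compound 2 (0.18 log units; within the scatter), lies within the scatter. Compound 3 gives only a limit, (the limit of > 5000 nM in this assay, at which 1 of the 3 values shown sits).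

Compound 4, `O=C(COc1ccc(CN2CC=C(c3c[nH]c4ccc(F)cc34)CC2)c(F)c1)NO`, differs from compound 1 by fluoro in place of hydrogen on an aromatic carbon. Within the data shown here, no measured step touches this position; the single step measured concerns the other aromatic ring and stays within the scatter. Compound 4 is therefore expected to sit close to compound 1, with an estimated step of a 1.1-fold lower number from compound 1 to compound 4 (0.02 log units; within the scatter) not beyond the scatter. For compound 4 the estimate in this assay is 900 nM, within 400 nM to 2000 nM.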

Compound 4, half-maximal inhibitory concentration: > 5000 nM
Compound 4 ended at the assay's limit; the forecaster's own chance of this, stated with the estimate: 5%; middle value at least 5.5-fold (0.74 log units) from the limit.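

In this assay, this position proves sensitive: fluoro ortho to a large group and meta to the (hydroxycarbamoyl)methoxy group gives an at least 5.2-fold higher number from compound 1 to compound 4 (0.72 log units; beyond the scatter). As far as these compounds go, the reading for compound 4 is a limit of the assay, not a number, so the full size of the step remains unknown. Unlike the step on the other aromatic ring, which stayed within the scatter, this single-atom change lies beyond it, and the limit is now shared: the limit of > 5000 nM in this assay, at which 2 of the 4 values shown sit.

From the compounds shown here alone, whether chloro, methoxy or an amine at this position would behave like fluoro remains open. So does whether the loss is specific to fluoro or extends to any group placed here.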